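Adding a benzyl ester side chain to compound 1

A few compounds are considered here, and "the series" means these few. Any claim that something is new, unique, unknown or untested is made for them only; others in the source may bear on it.

All three measured compounds were tested in a functional assay on the whole organism (Tail, strain ICR) with Mus musculus as the target, in the tail flick test, with a stated time of 60 min, at a dose of 25 umol/kg by the oral route; a higher number here means a stronger effect of the compound at the dose given, a lower number a weaker effect.

Compound 1, `O=C(CN(c1nc(Cl)nc2[nH]cnc12)C1CC1)NCC(=O)OCc1ccccc1`, gives 41.9%.
Compound 2, `CC[C@H](C)[C@H](NC(=O)CN(c1nc(Cl)nc2[nH]cnc12)C1CC1)C(=O)O`, gives 36%.
Compound 3, `O=C(OCc1ccccc1)[C@@H]1CCCN1C(=O)CN(c1nc(Cl)nc2[nH]cnc12)C1CC1`, gives 34.4%.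

Compound 1 has the highest of the three numbers, yet compound 2 and compound 3 both lie within the usual scatter of it, so the three cannot be ranked. Within the data shown here, no pair among them differs in only one place, so no single step can be read from the measured values. Compound 4, `O=C(CN(c1nc(Cl)nc2[nH]cnc12)C1CC1)N[C@@H](CCC(=O)OCc1ccccc1)C(=O)OCc1ccccc1`, differs from compound 1 by 2-(benzyloxycarbonyl)ethyl in place of hydrogen on a saturated chain carbon bound to an amide-type nitrogen and a carbonyl carbon. The measured compounds differ widely at the amide end and still give numbers within the scatter of each other, which suggests this part of the molecule moves the read-out little. The step of a number 4.9 percentage points lower from compound 1 to compound 4 (within the scatter) is therefore expected to stay within the scatter, with no clear direction. Compound 4 is estimated at 37%, with a range from 24% to 50%.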

Compound 4, a percentage reported as activity, at one dose (the size of the read-out at that dose, not a potency): 53.7%
For compound 4 the middle estimate is 16.7 percentage points below the measured one; measured number above the stated range.
By their numbers in this assay, from the lowest: compounds 3, 2 and 1 (each within the scatter of the next); then compound 4.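

In this assay, placing 2-(benzyloxycarbonyl)ethyl in place of hydrogen on the saturated chain carbon bound to an amide-type nitrogen and a carbonyl carbon gives a number 11.8 percentage points higher from compound 1 to compound 4 (beyond the scatter). Among these compounds, this is the first change in one place that can be read here, and it shows that this carbon accepts a group of 12 heavy atoms without losing effect at this dose, and that the read-out can respond to a change at this end of the molecule. No measurement is available that bears on the reason for this rise.

This single step cannot separate the roles of the ester, the aromatic ring and the chain itself. A carboxylic acid at the end of this chain, or a plain propyl chain on the same carbon, would be needed to tell which part matters.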